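The source may report more compounds than this note shows. Statements on the series, on what has been measured and on what is new or still open speak of the compounds shown alone.

Compound 1 `Cc1nn(-c2ncnc3nc[nH]c23)c2c1C(OC1CCCC1)CC(=O)N2` gives 62 nM in a functional assay on HEK293 cells for agonist activity at G-protein coupled receptor 39 (Homo sapiens), read by scintillation proximity assay and inositol phosphate accumulation, with a stated time of 75 min; on this read-out higher numbers stand for an effect only at larger amounts of compound and lower numbers for an effect already at smaller amounts. Compound 2 `Cc1nn(-c2ncnc3nc[nH]c23)c2c1C(c1ccc(OC(C)C)cc1)CC(=O)N2` gives 2700 nM in this assay. Compound 3 `Cc1nn(-c2ncnc3nc[nH]c23)c2c1C(OCc1ccc(F)cc1)CC(=O)N2` gives 126 nM in this assay.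

Compound 3 thus stands second highest of the three numbers, close to compound 1 and far from compound 2. The step to compound 4 `Cc1nn(-c2ncnc3nc[nH]c23)c2c1C(C(=O)N(C)c1ccccc1)CC(=O)N2` is methyl(phenyl)carbamoyl in place of (4-fluorobenzyl)oxy on a saturated ring carbon. Among the measured compounds shown here, two measured steps bear on it: a 44-fold higher number from compound 1 to compound 2 (1.64 log units; beyond the scatter), where a group joined through an oxygen gave way to a directly attached aryl group, and its reverse, a 21-fold lower number from compound 2 to compound 3 (1.33 log units; beyond the scatter). Compound 4 likewise loses the oxygen-joined group at that ring carbon, so a large step toward higher numbers in this assay is expected, a 12-fold higher number from compound 3 to compound 4 (1.08 log units; beyond the scatter). For compound 4 the expected value is 1500 nM, with a range from 300 nM to 8000 nM.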

Compound 4, half-maximal effective concentration: 5220 nM
Compound 4: middle estimate off by 3.5-fold (0.54 log units), on the low side; the measured number falls inside the stated range.
By their numbers in this assay, from the lowest: compound 1; then compound 3; then compounds 2 and 4 (each within the scatter of the next).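

In this assay, the methyl(phenyl)carbamoyl group, joined to the saturated ring carbon through its carbonyl, brings no separation from a directly attached aryl group: a 1.9-fold higher number from compound 2 to compound 4 (0.29 log units; within the scatter) stays within the scatter. Against the two oxygen-joined groups the gap is large, with a 41-fold higher number from compound 3 to compound 4 (1.62 log units; beyond the scatter) and an 84-fold higher number from compound 1 to compound 4 (1.93 log units; beyond the scatter), so all four compounds fit a split by the oxygen link, and none goes against it. Nothing available explains this split.

From the compounds shown here alone, it remains open whether a cyclopentylamino group at this carbon would fall with compound 1 and compound 3 or with compound 2 and compound 4. The same holds for a phenylcarbamoyl group that keeps the amide hydrogen in place of the methyl.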